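The source may hold more compounds than are shown below. What is called first, only, known or untested is meant among the compounds shown, and "the series" means these compounds.

Measured so far, in a functional assay on A549 cells (Homo sapiens) for inhibition; a higher number here means a weaker inhibitor, a lower number a stronger inhibitor:

Compound 1, `CC(C)c1cc(-c2n[nH]c(=O)n2-c2cccc(C(=O)NCCCCCCC(=O)NO)c2)c(O)cc1O`, gives 4600 nM.
Compound 2, `CNC(=O)CCCCCCCNC(=O)c1cccc(-n2c(-c3cc(C(C)C)c(O)cc3O)n[nH]c2=O)c1`, gives 4600 nM.
Compound 3, `CC(C)c1cc(-c2n[nH]c(=O)n2-c2cccc(C(=O)NCCCCCC(=O)NO)c2)c(O)cc1O`, gives 4600 nM.

All three share one core and differ only in the chain that carries the hydroxycarbamoyl or methylcarbamoyl end. Compound 3 stands level with the other two: the step of no change at the digits printed from compound 1 to compound 3 (within the scatter) and the step of no change at the digits printed from compound 2 to compound 3 (within the scatter) both stay within the scatter, as does no change at the digits printed from compound 1 to compound 2 (within the scatter).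

Compound 4, `CC(C)c1cc(-c2n[nH]c(=O)n2-c2cccc(C(=O)NCCCCC(=O)NO)c2)c(O)cc1O`, takes this one bond further. Its difference from compound 3 is hydroxycarbamoyl in place of (hydroxycarbamoyl)methyl on a saturated chain carbon, four bonds along the chain from an amide-type nitrogen. The two measured steps that shorten the chain, from compound 1 to compound 3 and from compound 2 to compound 3, each left the reading unchanged, so a further shortening of one chain carbon is expected to give no step beyond the scatter. For compound 4 the estimated step is no change at the digits printed from compound 3 to compound 4 (within the scatter), and compound 4 is expected to read about 4600 nM, between 2300 nM and 9200 nM.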

Compound 4, half-maximal inhibitory concentration: 4600 nM
The estimate for compound 4 equals the measured number at the digits printed; the measured number falls inside the stated range.
By their numbers in this assay, from the lowest: compounds 1, 2, 3 and 4 (each within the scatter of the next).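

Replacing (hydroxycarbamoyl)methyl with hydroxycarbamoyl, on the saturated chain carbon four bonds along from the amide-type nitrogen, gives no change at the digits printed from compound 3 to compound 4 (within the scatter) in this assay and so extends the flat reading to a shorter chain. The larger shortening, with hydroxycarbamoyl in place of 2-(hydroxycarbamoyl)ethyl, gives no change at the digits printed from compound 1 to compound 4 (within the scatter) as its result. With hydroxycarbamoyl in place of 3-(methylcarbamoyl)propyl, a change that also alters the chain end, the result is no change at the digits printed from compound 2 to compound 4 (within the scatter) and the reading again stays level.

No supporting evidence is available to explain these level readings.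

Still open, as far as these compounds go, is whether a chain shorter than that of compound 4 or longer than that of compound 1 would shift the reading. Also open, from the compounds shown here alone, is what a carboxylic acid or an amine at the chain end would do on the same shared core.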